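Fluoro in Place of Hydrogen: What to Expect

The source may report more compounds than this note shows. Statements on the series, on what has been measured and on what is new or still open speak of the compounds shown alone.

Within the data shown here, compound 1 `CN(C)C(=O)c1cc2cnc(Nc3ccc(NC(=O)C4(C(=O)Nc5ccccc5)CC4)cc3)nc2n1C1CCCC1` is one of two compounds measured in a functional assay on OVCAR-5 cells (Homo sapiens) for inhibition, read by CCK-8 assay, with a stated time of 72 h, tested at 1 uM; on this read-out higher numbers stand for more inhibition of growth at the one concentration tested and lower numbers for less inhibition of growth. In this assay compound 1 gives 52.1%, the smaller of the two numbers recorded, though only within the usual scatter. Compound 2 `CN(C)C(=O)c1cc2cnc(Nc3ccc(NC(=O)C4(C(=O)Nc5ccccc5F)CC4)cc3)nc2n1C1CCCC1` differs from compound 1 by a fluoro in place of hydrogen on an aromatic carbon, and in this assay compound 2 gives 58%, which is a number 5.9 percentage points higher from compound 1 to compound 2 (within the scatter). On this read-out the two compounds cannot be told apart.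

Compound 3 `CN(C)C(=O)c1cc2cnc(Nc3ccc(NC(=O)C4(C(=O)Nc5cccc(F)c5)CC4)cc3)nc2n1C1CCCC1` has not yet been measured. It differs from compound 1 as follows: fluoro in place of hydrogen on an aromatic carbon. Among the measured compounds shown here, the only measured step that bears on this change is the one from compound 1 to compound 2, where a fluoro likewise enters in place of a hydrogen on an aromatic carbon, and that step was small. A step of similar size is therefore expected here, with no clear direction: the expected step is a number 2.9 percentage points higher from compound 1 to compound 3 (within the scatter), staying within the scatter. In this assay compound 3 is estimated to give about 55%, most likely between 42% and 68%.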

Compound 3, percent growth inhibition at one concentration: 26.3%
The estimate for compound 3 lay 28.7 percentage points above the measured number, and the stated range ends above it.
By their numbers in this assay, from the lowest: compound 3; then compounds 1 and 2 (each within the scatter of the next).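

The same exchange of hydrogen for fluoro does not have one effect on this phenyl ring: in this assay the fluoro that sits meta to a large group gives a number 25.8 percentage points lower from compound 1 to compound 3 (beyond the scatter) and clearly reduces growth inhibition, whereas the fluoro of the 2-fluorophenyl group gives a number 5.9 percentage points higher from compound 1 to compound 2 (within the scatter) and leaves no readable change. Moving the single fluoro around the ring, from 2-fluorophenyl to 3-fluorophenyl with the rest of the molecule unchanged, gives a number 31.7 percentage points lower from compound 2 to compound 3 (beyond the scatter) and shows that on this read-out the place of the fluoro counts, not just its presence. Nothing available here accounts for this difference between the two positions.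

On these data alone, it remains open whether the loss belongs to fluoro itself or to any group at this place on the ring, a question that a chloro, a methoxy or an amine on the same ring carbon could help to settle. As far as these compounds go, with a read-out at one concentration, it also remains open whether the gap between these compounds would hold across other concentrations.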